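The source may hold more compounds than are shown below. What is called first, only, known or untested is meant among the compounds shown, and "the series" means these compounds.

Compound 1 `CC(C)(O)C#Cc1cc(C(O)(C(F)(F)F)C(F)(F)F)cnc1N1CCN(S(=O)(=O)c2ccc(N)nc2)CC1` carries a 3-hydroxy-3-methylbut-1-yn-1-yl group on the shared core. In an ADME assay (liver) for metabolic stability, with Liver microsome (Homo sapiens) as the target, using microsomes and NADPH, with a stated time of 30 min, tested at 1 uM (on this read-out lower numbers stand for slow clearance and higher numbers for fast clearance), compound 1 gives only a limit, < 14 mL.min-1.g-1, and so stands at the limit of < 14 mL.min-1.g-1 in this assay, at which 1 of the 3 values shown sits, rather than at a number. Compound 2 `Nc1ccc(S(=O)(=O)N2CCN(c3ncc(C(O)(C(F)(F)F)C(F)(F)F)cc3-c3cccnc3)CC2)cn1` carries pyridin-3-yl in its place, and in this assay compound 2 gives 17 mL.min-1.g-1. Compound 3 `Nc1ccc(S(=O)(=O)N2CCN(c3ncc(C(O)(C(F)(F)F)C(F)(F)F)cc3-c3cnccc3F)CC2)cn1` carries 4-fluoropyridin-3-yl, and in this assay compound 3 gives 17 mL.min-1.g-1. The measured steps are an at least 1.2-fold higher number from compound 1 to compound 2 (0.08 log units; that floor lies within the scatter) and an at least 1.2-fold higher number from compound 1 to compound 3 (0.08 log units; that floor lies within the scatter), while no change at the digits printed from compound 2 to compound 3 (within the scatter).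

Compound 4 `Nc1ccc(S(=O)(=O)N2CCN(c3ncc(C(O)(C(F)(F)F)C(F)(F)F)cc3-c3ccc4scnc4c3)CC2)cn1` makes a change of the same kind: 1,3-benzothiazol-5-yl in place of 3-hydroxy-3-methylbut-1-yn-1-yl on an aromatic carbon. The two steps from compound 1 to an aromatic group in place of the alkyne both bear on it, and both gave only a floor that lies within the scatter. Compound 4 is therefore expected to show the step of an at least 1.7-fold higher number from compound 1 to compound 4 (0.25 log units; that floor lies within the scatter), of the same kind as those seen for compound 2 and compound 3. In this assay compound 4 is estimated at 25 mL.min-1.g-1, with a range from 12 mL.min-1.g-1 to 55 mL.min-1.g-1.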

Compound 4, intrinsic clearance in microsomes: 39 mL.min-1.g-1
Compound 4: the middle estimate sits 1.6-fold (0.19 log units) below what was measured; the range from low to high includes it.
By their numbers in this assay, from the lowest: compounds 2 and 3 (each within the scatter of the next); then compound 4. At a limit, below all of these: compound 1.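

In this assay, this position now gives a step that clears the scatter, an at least 2.7-fold higher number from compound 1 to compound 4 (0.44 log units; beyond the scatter), whereas the two earlier replacements of the 3-hydroxy-3-methylbut-1-yn-1-yl group gave only floors within it. Compound 1 is held at a limit and not at a number, so this step too is only a floor: the limit of < 14 mL.min-1.g-1 in this assay, at which 1 of the 4 values shown sits.

Among the compounds shown here, the aromatic groups at this position also separate for the first time, with a 2.3-fold higher number from compound 2 to compound 4 (0.36 log units; beyond the scatter) and a 2.3-fold higher number from compound 3 to compound 4 (0.36 log units; beyond the scatter), so the 1,3-benzothiazol-5-yl group, with its five-membered and six-membered aromatic rings, stands apart from pyridin-3-yl and 4-fluoropyridin-3-yl. The compounds shown do not tell whether the higher number goes with the sulfur-bearing five-membered ring or with the larger group as a whole. They also leave open how a morpholine or a simple phenyl ring at this position would read in this assay.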